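Shortened unsaturated chain on the nitrogen substituent of compound 3

The source may hold more compounds than are shown below. What is called first, only, known or untested is meant among the compounds shown, and "the series" means these compounds.

Working notes on the series. Three compounds carry numbers in a functional assay on MCF7 cells (Homo sapiens) for cytotoxicity; a higher number here means that more compound is needed for the effect, a lower number that less compound is needed. Compound 1 `COc1cc(Cc2nc3c(N)ncnc3n2CCCCO)cc(OC)c1OC` gives 76900000 nM. Compound 2 `COc1cc(Cc2nc3c(N)ncnc3n2CC(C)CCCO)cc(OC)c1OC` gives 8770000 nM. Compound 3 `CCCCCn1c(Cc2cc(OC)c(OC)c(OC)c2)nc2c(N)nc(F)nc21` gives 286000000 nM, the highest of the three numbers; of the other two, compound 1 lies closer to it and compound 2 further away.

Among the measured compounds shown here, the one step measured between compounds that differ in a single place is an 8.8-fold lower number from compound 1 to compound 2 (0.94 log units; beyond the scatter). That step exchanges one hydroxylated chain for another on a core without fluorine and is a modest move.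

Compound 4 `C=CCCn1c(Cc2cc(OC)c(OC)c(OC)c2)nc2c(N)nc(F)nc21` differs from compound 3 by vinyl in place of propyl on a saturated chain carbon, two bonds along the chain from an aromatic nitrogen. For the measured compounds named here, no measured step removes chain carbons or introduces a double bond on this chain, and the step from compound 1 to compound 2 concerns a different kind of chain on a different core, so it does not bear directly on this change. The two chains in compound 3 and compound 4 are both short, unfunctionalised and without donors or acceptors. On this basis no move beyond the scatter is expected; the step from compound 3 to compound 4 is estimated as a 1.1-fold lower number from compound 3 to compound 4 (0.06 log units; within the scatter). Compound 4 is therefore expected to give about 250000000 nM, within a range from 60000000 nM to 1000000000 nM in this assay.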

Compound 4, half-maximal effective concentration: 102000000 nM
Compound 4: the middle estimate sits 2.5-fold (0.39 log units) above what was measured; the range from low to high includes it.
By their numbers in this assay, from the lowest: compound 2; then compounds 1 and 4 (each within the scatter of the next); then compound 3.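

In this assay, among the compounds shown here, vinyl in place of propyl on a saturated chain carbon, two bonds along the chain from an aromatic nitrogen, gives a 2.8-fold lower number from compound 3 to compound 4 (0.45 log units; beyond the scatter), so a change on an unfunctionalised chain on the fluorine-bearing core moves the number beyond the scatter, which the earlier compounds, whose one single-place step concerns hydroxylated chains on the core without fluorine, could not show. The two single-place steps now available both go to a lower number, although that covers only these two pairs and they share neither chain type nor core. Nothing measured here explains the step from pentyl to but-3-en-1-yl, which removes chain carbon and adds a double bond outside aromatic rings at the same time.

The compounds shown leave open which of those two parts of the change carries the step, and a butyl chain on the same nitrogen of the fluorine-bearing core would separate them. Also open, as far as these compounds go, is how an amine or a carboxylic acid at the end of this chain, or a longer chain, would sit against these numbers.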